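This account rests on a few compounds, and the source may have more. Where it says the series, first, only, none or still open, it means among the compounds named here.

Measured so far in a functional assay on T47D cells (Homo sapiens) for inhibition, read by CCK-8 assay, with a stated time of 72 h, tested at 10 uM; a higher number here means more inhibition of growth at the concentration tested, a lower number less inhibition of growth:
Compound 1 `Cc1cccc(NC(=O)C2(C(=O)Nc3ccc(Nc4ncc5cc(C(=O)N(C)C)n(C6CCCC6)c5n4)cc3)CC2)c1`: 95.3%
Compound 2 `CN(C)C(=O)c1cc2cnc(Nc3ccc(N)cn3)nc2n1C1CCCC1`: 61.1%
Compound 3 `CN(C)C(=O)c1cc2cnc(Nc3ccc(NC(=O)C4(C(=O)Nc5cccc(O)c5)CC4)cc3)nc2n1C1CCCC1`: 83.7%

Among these three, compound 3, at 83.7%, stands second, under compound 1 and well over compound 2. The next compound, compound 4 `COc1cccc(NC(=O)C2(C(=O)Nc3ccc(Nc4ncc5cc(C(=O)N(C)C)n(C6CCCC6)c5n4)cc3)CC2)c1`, differs from compound 3 in one place: methyl in place of hydrogen on an oxygen on an aromatic ring. This is methyl in place of hydrogen on an oxygen on an aromatic ring, which turns 3-hydroxyphenyl into 3-methoxyphenyl.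

Among the compounds with values here, one measured step bears on this change: a number 11.6 percentage points lower from compound 1 to compound 3 (beyond the scatter), with hydroxy in place of methyl on an aromatic carbon. It is modest, yet it shows that this assay responds to a swap of this group. Within the data shown here, it is only a guide, since methoxy is not methyl and no measured pair goes directly from hydroxy to methoxy. Compound 1, which has no hydroxy, gives 95.3%, so a small rise is expected from capping the hydroxy, smaller than that earlier step and possibly not beyond the scatter. The expected step is a number 6.3 percentage points higher from compound 3 to compound 4 (within the scatter). Compound 4 is estimated at 90%, with an expected range from 79% to 99%.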

Compound 4, percent growth inhibition at one concentration: 93.5%
Compound 4: the middle estimate sits 3.5 percentage points below what was measured, and the stated range covers the measured number.
By their numbers in this assay, from the lowest: compound 2; then compounds 3, 4 and 1 (each within the scatter of the next, the first and the last beyond it).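

In this assay the methoxy group of compound 4 stands apart neither from the hydroxy group nor from the methyl group, as the step from hydroxy to methoxy (a number 9.8 percentage points higher from compound 3 to compound 4 (within the scatter)) and the step from methyl to methoxy (a number 1.8 percentage points lower from compound 1 to compound 4 (within the scatter)) both lie within the scatter. Until now this position had shown only one step, the one beyond the scatter between methyl and hydroxy, and compound 4 adds a third group whose steps to both of the others are smaller and within the scatter, so this change on the oxygen has no effect here that can be told apart from the scatter. No evidence is available to explain these readings.

The compounds shown leave open whether an ethoxy group, an amine or a carboxylic acid in this place would keep the inhibition of growth in the same range as the methoxy group does. They also leave open whether compounds 1, 3 and 4 would separate at other concentrations, since each was read at a single concentration.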